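Trimming an Isopropyl to a Methyl in a Weak Series

This account rests on a few compounds, and the source may have more. Where it says the series, first, only, none or still open, it means among the compounds named here.

Measured compounds:
Compound 1 `CC(C)c1ccc(-c2nc(SCc3cn(CC(=O)NC(=O)Nc4ccccn4)nn3)nc(Nc3ccccc3Cl)c2C#N)cc1`: 43700 nM
Compound 2 `Cc1ccc(Nc2nc(SCc3cn(CC(=O)NC(=O)Nc4ccccn4)nn3)nc(-c3ccc(C(C)C)cc3)c2C#N)cc1`: > 64000 nM

In a functional assay on MCF7 cells (Homo sapiens) for inhibition, read by MTT assay, with a stated time of 72 h (on this read-out lower numbers stand for stronger inhibition and higher numbers for weaker inhibition), compound 1 gives 43700 nM. For compound 2 this assay returns only a limit, > 64000 nM, and so no exact number; it is the limit of > 64000 nM in this assay, at which 1 of the 2 values shown sits. Going by the values given here, the one measured step, an at least 1.4-fold higher number from compound 1 to compound 2 (0.16 log units; that floor lies within the scatter), is a change on the amine-bearing ring and its floor sits within the scatter.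

Compound 3 `Cc1ccc(Nc2nc(SCc3cn(CC(=O)NC(=O)Nc4ccccn4)nn3)nc(-c3ccc(C)cc3)c2C#N)cc1` differs from compound 2 by methyl in place of isopropyl on an aromatic carbon. None of the measured steps touches this position, so nothing shown bears directly on it. Compound 2 stands at a limit already, and compound 3 is expected to behave much the same, with the step that the limit leaves unreadable from compound 2 to compound 3 expected to stay within the scatter. Compound 3 is therefore estimated at 70000 nM, in the range 30000 nM to 160000 nM, most likely again reported only as a limit.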

Compound 3, half-maximal inhibitory concentration: 39600 nM
The estimate for compound 3 lay 1.8-fold (0.25 log units) above the measured number, and the stated range covers the measured number.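

Going by these compounds alone, this is the first view of the position, and in this assay the change from 4-isopropylphenyl to 4-methylphenyl gives an at least 1.6-fold lower number from compound 2 to compound 3 (0.20 log units; that floor lies within the scatter). With the methyl group, this assay returns an exact number for compound 3, 39600 nM, so this smaller group at least allows a reading of the compound's strength. Compound 2 has only a limit, so the true size of the step stays unknown and may differ from its printed floor: the limit of > 64000 nM in this assay, at which 1 of the 3 values shown sits.

The compounds shown carry only isopropyl and methyl at this place, so it remains open how a methoxy group, a carboxylic acid or a longer chain such as butyl would read there. On these data alone, it is also open whether the same trim would give a similar result with the 2-chlorophenyl group of compound 1 on the nitrogen.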